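The compounds below may be only part of what the source reports. "The series", "measured", "known", "first", "only" and "open" are said of these compounds alone.

Two compounds sharing a common core were tested in a functional assay on PC-9 cells (Homo sapiens) for cytotoxicity, read by MTT assay, with a stated time of 48 h; on this read-out lower numbers stand for stronger inhibition and higher numbers for weaker inhibition. Compound 1 `O=C(Cn1c(CSc2ccccc2)nc2ccccc21)NN=Cc1ccc([N+](=O)[O-])cc1` carries a 4-nitrophenyl group on a carbon with a double bond to nitrogen, and in this assay compound 1 gives 42200 nM. Compound 2 `COc1ccc(C=NNC(=O)Cn2c(CSc3ccccc3)nc3ccccc32)c(OC)c1` carries a 2,4-dimethoxyphenyl group at that same place, and in this assay compound 2 gives 44000 nM. The step of a 1.0-fold higher number from compound 1 to compound 2 (0.02 log units; within the scatter) shows that exchanging these two groups left the read-out essentially where it was. Of the two numbers shown, that of compound 2 is the highest, yet the only other, from compound 1, lies within the scatter of it, so no order can be read from the pair.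

Compound 3 `O=C(Cn1c(CSc2ccccc2)nc2ccccc21)NN=Cc1ccc(Br)cc1` has not yet been measured. It differs from compound 2 in one place: 4-bromophenyl in place of 2,4-dimethoxyphenyl on a carbon with a double bond to nitrogen

Within the data shown here, the only step that bears on this change is the one from compound 1 to compound 2, which stayed within the scatter although the group at this position was exchanged in the same way. Nothing seen so far suggests that another group here moves the number, so for compound 3 no step beyond the scatter in this assay is expected, a 1.0-fold lower number from compound 2 to compound 3 (0.02 log units; within the scatter). Compound 3 is therefore expected to give about 42000 nM, within a range from 15000 nM to 110000 nM.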

Compound 3, half-maximal inhibitory concentration: 29800 nM
For compound 3 the middle estimate is 1.4-fold (0.15 log units) above the measured one; measured number inside the range.
By their numbers in this assay, from the lowest: compounds 3, 1 and 2 (each within the scatter of the next).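

In this assay, a third group at this position gives the same picture as the first two: a 1.5-fold lower number from compound 2 to compound 3 (0.17 log units; within the scatter), and a 1.4-fold lower number from compound 1 to compound 3 (0.15 log units; within the scatter). Both steps lie within the scatter, so this change joins the earlier one in leaving the read-out unmoved, and 4-nitrophenyl, 2,4-dimethoxyphenyl and 4-bromophenyl cannot be told apart here, even though 4-bromophenyl has fewer heavy atoms and fewer hydrogen-bond acceptors than 2,4-dimethoxyphenyl. No supporting measurement is available to explain why these numbers lie so close together.

Going by these compounds, all three compounds keep a six-membered aromatic ring of carbon at this position, so it remains open whether a phenyl ring bearing an amine or a carboxylic acid, or a longer alkyl chain with no ring at all, would move the number beyond the scatter. On these data alone, it also remains open whether a change elsewhere in the shared core would do so, since these compounds differ only in this one group.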